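Opening the azepane ring to an aminoethyl chain

The source may hold more compounds than are shown below. What is called first, only, known or untested is meant among the compounds shown, and "the series" means these compounds.

Compound 1 `Cn1cc(NC(=O)c2cnc3ccc(N4CCC[C@@H](N)C4)nn23)c(C(F)F)n1`: 17800 nM
Compound 2 `Cn1cc(NC(=O)c2cnc3ccc(N[C@@H]4CCCNC4)nn23)c(C(F)F)n1`: 1200 nM
Compound 3 `Cn1cc(NC(=O)c2cnc3ccc(N[C@@H]4CCCCNC4)nn23)c(C(F)F)n1`: 1200 nM

In a functional assay on TMD8 cells (Homo sapiens) for cytotoxicity, read by CCK-8 assay, with a stated time of 72 h (on this read-out higher numbers stand for weaker inhibition and lower numbers for stronger inhibition), compound 3 gives 1200 nM. It sits level with compound 2, and the two share the low end of the three numbers, while compound 1 alone stands higher.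

The next compound, compound 4 `Cn1cc(NC(=O)c2cnc3ccc(NCCN)nn23)c(C(F)F)n1`, is reached by this change: 2-aminoethyl in place of azepan-3-yl on a nitrogen on an aromatic ring. In words, 2-aminoethyl stands in place of azepan-3-yl on a nitrogen on an aromatic ring, so the ring is lost.

Two kinds of measured step bear on this. The swap of azepan-3-yl for piperidin-3-yl gave no change at the digits printed from compound 2 to compound 3 (within the scatter), so that one change of ring left the number untouched. The large steps, a 15-fold lower number from compound 1 to compound 2 (1.17 log units; beyond the scatter) and a 15-fold lower number from compound 1 to compound 3 (1.17 log units; beyond the scatter), came with replacing 3-aminopiperidin-1-yl by a ring-bearing amino group. Compound 4 keeps such an amino group, as (2-aminoethyl)amino, so a return to the level of compound 1 seems unlikely. Among the compounds with values here, no measured compound lacks a ring, however, which leaves this step poorly constrained.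

A moderate rise toward weaker inhibition is expected, estimated as a 2.5-fold higher number from compound 3 to compound 4 (0.40 log units; beyond the scatter). For compound 4 the expected value is 3000 nM, with an estimated range of 900 nM to 12000 nM.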

Compound 4, half-maximal inhibitory concentration: 17700 nM
Beside the measured number, compound 4's estimate is 5.9-fold (0.77 log units) below it, outside the stated range (above it).
By their numbers in this assay, from the lowest: compounds 2 and 3 (each within the scatter of the next); then compounds 4 and 1 (each within the scatter of the next).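

In this assay the change to 2-aminoethyl proved large, with a 15-fold higher number from compound 3 to compound 4 (1.17 log units; beyond the scatter) and a 15-fold higher number from compound 2 to compound 4 (1.17 log units; beyond the scatter) both beyond the scatter, although the earlier swap between the two rings had left the number unchanged. Keeping an amino group on the aromatic carbon was therefore not enough to hold the lower numbers of compounds 2 and 3: the chain stands within the scatter of 3-aminopiperidin-1-yl, with a 1.0-fold lower number from compound 1 to compound 4 (0.00 log units; within the scatter) on this read-out, so at this position the group carried on the nitrogen decides the result as much as the linking nitrogen does. Nothing measured here explains why the number moves with this group.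

The compounds shown do not separate the loss of the ring from the loss of heavy atoms or of the defined stereocentre, as 2-aminoethyl differs from azepan-3-yl in all three at once. A longer chain such as 4-aminobutyl, a chain ending in a dimethylamine, or a smaller ring such as pyrrolidin-3-yl on the same nitrogen would bear on these open points.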